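This account rests on a few compounds, and the source may have more. Where it says the series, first, only, none or still open, it means among the compounds named here.

Measured compounds in this series:
compound 1, `O=c1cc(Cc2c(F)cccc2F)nc(SC2CCCC2)[nH]1` — > 200000 nM
compound 2, `CC(c1cc(O)nc(SC2CCCCC2)n1)c1c(Cl)cccc1Cl` — > 200000 nM
compound 3, `CCC(c1cc(O)nc(SC2CCCCC2)n1)c1c(Cl)cccc1Cl` — 200000 nM

All three were run in a functional assay on MT4 cells (Homo sapiens) for cytotoxicity; a higher number here means that more compound is tolerated, a lower number that less compound is tolerated. For compound 1 the value > 200000 nM is a limit of the assay, not a number. For compound 2 the value > 200000 nM is likewise a limit. Compound 3 gives 200000 nM in this assay. Two of the three values sit at the limit of > 200000 nM in this assay, at which 2 of the 3 values shown sit.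

Compound 2 and compound 3 differ by methyl in place of hydrogen on a saturated chain carbon, two bonds along the chain from two aromatic carbons. Across that change the read-out moved by a number no higher from compound 2 to compound 3 (the limit leaves the size open); with compound 2 at a limit, the size of this step cannot be read.

Compound 4, `CC(c1cc(=O)[nH]c(SC2CCCC2)n1)c1c(F)cccc1F`, has not yet been measured in this assay. It differs from compound 1 by methyl in place of hydrogen on a saturated chain carbon bound to two aromatic carbons. This is the same kind of change as that from compound 2 to compound 3, though not the same: there the methyl enters on a saturated chain carbon two bonds along the chain from two aromatic carbons, here on a saturated chain carbon bound to two aromatic carbons. The difference between the core of compound 1 and the core of compound 2 is not broken down here.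

For the measured compounds named here, the one measured step of this kind, a number no higher from compound 2 to compound 3 (the limit leaves the size open), gives no sign of a change in tolerated concentration. The estimate for compound 4 rests on compound 1 at its limit > 200000 nM. The estimated step for compound 4 is therefore a number no higher from compound 1 to compound 4 (the limit leaves the size open). Compound 4 is expected to give about 200000 nM in this assay, between 100000 nM and 400000 nM, most likely reported again as a limit.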

Compound 4, half-maximal cytotoxic concentration: > 200000 nM
Compound 4 gave a limit, no number; the forecaster's own chance of this, stated with the estimate: 70%; the middle value sits exactly at the limit.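

The step between compound 1 and compound 4 cannot be read, as both values are limits of the assay and neither is a number: the limit of > 200000 nM in this assay, at which 3 of the 4 values shown sit.

Still open is whether methyl in place of hydrogen on a saturated chain carbon bound to two aromatic carbons changes the tolerated concentration at all, as the compounds shown give no number for either side of this step.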